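Cyclohexanol to Aminocyclopentyl on a Fused Core

This account rests on a few compounds, and the source may have more. Where it says the series, first, only, none or still open, it means among the compounds named here.

Compound 1 `Nc1ncnc2c1c(Oc1cc(C(F)(F)F)ccn1)nn2[C@@H]1CCCC[C@H]1O` — > 2.41 h
Compound 2 `Nc1ncnc2c1c(Oc1cc(O)ccn1)nn2C1CCC(F)(F)CC1` — > 2.41 h

In an ADME assay on microsomes from liver (Homo sapiens) for metabolic stability, read by LC-MS, using NADPH, with a stated time of 10 min, tested at 10 uM (a higher number here means that the compound lasts longer, a lower number that the compound disappears faster), compound 1 gives > 2.41 h, which is a limit of the assay rather than a number. Compound 2 likewise gives > 2.41 h, also a limit. Both values sit at the limit of > 2.41 h in this assay, at which 2 of the 2 values shown sit, so compound 1 cannot be placed relative to compound 2. Compound 3 `Nc1ncnc2c1c(Oc1cc(C(F)(F)F)ccn1)nn2[C@@H]1CC[C@H](N)C1` has not yet been measured; it differs from compound 1 by 3-aminocyclopentyl in place of 2-hydroxycyclohexyl on an aromatic nitrogen. Among the compounds with values here, with no measured step to draw on, the step of an at least 1.2-fold lower number from compound 1 to compound 3 (0.08 log units; that floor lies within the scatter) is expected to be small. Compound 3 is therefore estimated at 2 h, between 0.8 h and 4 h.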

Compound 3, half-life: > 2.41 h
Compound 3 gave a limit, no number; the forecaster's own chance of this, stated with the estimate: 55%; middle value at least 1.2-fold (0.08 log units) away from the limit.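

Within the data shown here, compound 3, like compound 1, gives only a limit in this assay, and no step between them can be read: the limit of > 2.41 h in this assay, at which 3 of the 3 values shown sit. The compounds shown leave open whether 3-aminocyclopentyl in place of 2-hydroxycyclohexyl changes the half-life at all.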